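The source may report more compounds than this note shows. Statements on the series, on what has been measured and on what is new or still open speak of the compounds shown alone.

Compound 1 `CCCOc1ccc(CN(Cc2ccc(C(C)(C)C)cc2)Cc2cc3cc(C)ccc3[nH]c2=O)cc1` gives > 5000 nM in a toxicity assay on MDCK cells (Canis lupus familiaris) for cytotoxicity, read by crystal violet staining, with a stated time of 48 h (a higher number here means that more compound is tolerated, a lower number that less compound is tolerated), a limit of the assay.
Compound 2 `Cc1ccc2[nH]c(=O)c(CN(Cc3ccc(C(N)=O)cc3)Cc3ccc(C(C)(C)C)cc3)cc2c1` gives > 5000 nM in this assay, again only a limit.
Compound 3 `Cc1ccc2[nH]c(=O)c(CN(Cc3ccc(OC(F)(F)F)cc3)Cc3ccc(C(C)(C)C)cc3)cc2c1` gives > 5000 nM in this assay, also a limit.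

Compound 3 therefore stands at the top of what the numbers show: no value among the three is a number, and all sit at the same limit, (the limit of > 5000 nM in this assay, at which 3 of the 3 values shown sit). The steps between the measured compounds cannot be read for that reason: a step that the two limits leave unreadable from compound 1 to compound 2, a step that the two limits leave unreadable from compound 1 to compound 3 and a step that the two limits leave unreadable from compound 2 to compound 3 all lie between two limits.

Compound 4 `Cc1ccc2[nH]c(=O)c(CN(Cc3ccc(C#N)cc3)Cc3ccc(C(C)(C)C)cc3)cc2c1` is the next member of the series. The change from compound 3 is cyano in place of trifluoromethoxy on an aromatic carbon. For the measured compounds named here, the steps that bear on this position, from compound 1 to compound 3 and from compound 2 to compound 3, both exchange the group at the same aromatic carbon and both left the limit untouched, so nothing measured points to a change in this assay beyond the scatter. Compound 4 is accordingly expected to sit at the limit as well, with an estimated step that the limit leaves unreadable from compound 3 to compound 4. The estimate for compound 4 is 10000 nM, with a range from 3000 nM to 30000 nM.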

Compound 4, half-maximal cytotoxic concentration: > 5000 nM
Compound 4 gave a limit, no number (the forecaster's own chance of this, stated with the estimate: 85%); the middle value is on the limit's open side.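

In this assay compound 4 gives > 5000 nM, a limit and not a number. The steps from compound 1, compound 2 and compound 3 to compound 4 therefore cannot be read, as all four compounds sit at the same limit: the limit of > 5000 nM in this assay, at which 4 of the 4 values shown sit. The compounds shown leave open what the half-maximal cytotoxic concentration of any of them is, and whether exchanging the group on the aromatic carbon alters it at all.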